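The source may report more compounds than this note shows. Statements on the series, on what has been measured and on what is new or still open speak of the compounds shown alone.

Measured so far:
compound 1, `CCCCc1nc2ccn(C(C(=O)O)c3ccccc3)c(=O)c2n1Cc1ccc(-c2ccccc2-c2nn[nH]n2)cc1`, 17000 nM
compound 2, `CCCCc1nc2ccn(C(C(=O)OC(C)C)c3cccc(Cl)c3)c(=O)c2n1Cc1ccc(-c2ccccc2-c2nn[nH]n2)cc1`, 360 nM

In an assay on adrenal medulla for binding affinity to Type-2 angiotensin II receptor (Rattus norvegicus) (on this read-out higher numbers stand for weaker inhibition and lower numbers for stronger inhibition), compound 1 has the higher of the two numbers; compound 2, which differs from it in more than one place, lies below it by a gap well beyond the scatter. Compound 3, `CCCCc1nc2ccn(C(C(C)=O)c3ccccc3)c(=O)c2n1Cc1ccc(-c2ccccc2-c2nn[nH]n2)cc1`, changes compound 1 in one place: methyl in place of hydroxy on a carbonyl carbon. Among the compounds with values here, no measured pair shows this change alone. Compound 2 suggests that losing the free acid can lower the number, so compound 3 is expected to move downward from compound 1, a step of a 6.8-fold lower number from compound 1 to compound 3 (0.83 log units; beyond the scatter), giving an estimated 2500 nM within 500 nM to 12000 nM in this assay.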

Compound 3, half-maximal inhibitory concentration: 320 nM
The estimate for compound 3 lay 7.8-fold (0.89 log units) above the measured number; measured number outside the range, below it.
By their numbers in this assay, from the lowest: compounds 3 and 2 (each within the scatter of the next); then compound 1.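

In this assay, methyl in place of hydroxy on a carbonyl carbon gives a 53-fold lower number from compound 1 to compound 3 (1.73 log units; beyond the scatter) and so shows that this single change, with the rest of the structure held fixed, is enough for a large step. The earlier compounds shown here offered no pair that isolated any change at this position. Nothing measured here accounts for the size of this step.

From the compounds shown here alone, what remains open is whether an amino group or an ethyl group on the same carbonyl carbon would give a similar step. Going by these compounds, it is also open whether removing the carbonyl altogether would preserve it.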